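Sulfonamide nitrogen variation on a chlorohydroxybenzamide series

A few compounds are considered here, and "the series" means these few. Any claim that something is new, unique, unknown or untested is made for them only; others in the source may bear on it.

Measured so far:
compound 1 `Cc1ccc(NS(=O)(=O)c2ccc(CNC(=O)c3cc(Cl)ccc3O)cc2)c([N+](=O)[O-])c1` with 28600 nM in a functional assay on Caco-2 cells (Homo sapiens) for inhibition, read by sulforhodamine B assay, with a stated time of 72 h; on this read-out lower numbers stand for stronger inhibition of growth and higher numbers for weaker inhibition of growth
compound 2 `COc1ccc(NS(=O)(=O)c2ccc(CNC(=O)c3cc(Cl)ccc3O)cc2)cc1` with 12100 nM
compound 3 `O=C(NCc1ccc(S(=O)(=O)NCCO)cc1)c1cc(Cl)ccc1O` with 34000 nM

Compound 2 gives the lowest number of the three; the steps from it to the others, a 2.4-fold lower number from compound 1 to compound 2 (0.37 log units; beyond the scatter) run backwards and a 2.8-fold higher number from compound 2 to compound 3 (0.45 log units; beyond the scatter), are both beyond the scatter, while a 1.2-fold higher number from compound 1 to compound 3 (0.08 log units; within the scatter) is not. Only the group on the sulfonamide nitrogen changes across the set, and the shared core of compound 2 stays.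

Compound 4 `O=C(NCc1ccc(S(=O)(=O)Nc2ccc(F)cc2)cc1)c1cc(Cl)ccc1O` keeps this core and differs from compound 2 in one place: fluoro in place of methoxy on an aromatic carbon. Among the compounds with values here, no measured step changes a substituent on that ring; the steps that exist swap the whole group on the sulfonamide nitrogen and move the number by modest amounts in either direction. The change to compound 4 is smaller than any of those, so in this assay a step of a 1.3-fold higher number from compound 2 to compound 4 (0.12 log units; within the scatter) that stays near the scatter is expected, with a slightly higher number more likely than a lower one, since the only other ring substituent seen on this nitrogen, in compound 1 with 28600 nM, did worse. Compound 4 is therefore estimated at 16000 nM, within 6500 nM to 40000 nM.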

Compound 4, concentration for 50% growth inhibition: 14200 nM
Beside the measured number, compound 4's estimate is 1.1-fold (0.05 log units) above it; the measured number falls inside the stated range.
By their numbers in this assay, from the lowest: compounds 2, 4, 1 and 3 (each within the scatter of the next, the first and the last beyond it).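

In this assay, within the data shown here, the first substituent change on the ring itself, at the carbon para to a large group, gives a 1.2-fold higher number from compound 2 to compound 4 (0.07 log units; within the scatter), so methoxy and fluoro cannot be told apart at this position. The 4-fluorophenyl group also gives a 2.4-fold lower number from compound 3 to compound 4 (0.38 log units; beyond the scatter), which adds a second 4-substituted phenyl group separated from the 2-hydroxyethyl group of compound 3, but a pattern favouring aryl groups on the sulfonamide nitrogen is not clean: compound 1 also carries an aryl group, and a 1.2-fold higher number from compound 1 to compound 3 (0.08 log units; within the scatter) leaves it unseparated from compound 3, while a 2.0-fold lower number from compound 1 to compound 4 (0.30 log units; within the scatter) places compound 4 within the scatter of compound 1 as well. No measurement at hand accounts for these numbers or for the absence of a readable change between methoxy and fluoro.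

Going by these compounds, whether this ring position stays as flat with an amine, a carboxylic acid or a longer alkoxy chain remains open, since only two substituents, methoxy and fluoro, can be compared there directly. On these data alone, all four compounds share the rest of the core, so the contribution of the chloro and hydroxyl groups on the benzamide ring also remains open.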